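Adding a methyl to a hydroxyethoxy side chain

This account rests on a few compounds, and the source may have more. Where it says the series, first, only, none or still open, it means among the compounds named here.

Measured compounds in a functional assay on NCI-H460 cells (Homo sapiens) for antiproliferative activity, read by MTT assay, with a stated time of 72 h; a lower number here means a stronger inhibitor, a higher number a weaker inhibitor:
compound 1 `CC(C)(O)COc1ccc2c(Oc3ccc(Nc4nccc5[nH]cc(-c6ccccc6)c(=O)c45)cc3F)ccnc2c1` gives 3600 nM
compound 2 `COCCOc1cc2nccc(Oc3ccc(Nc4nccc5[nH]cc(-c6ccc(F)cc6)c(=O)c45)cc3F)c2cc1OC` gives 3000 nM
compound 3 `O=c1c(-c2ccc(F)cc2)c[nH]c2ccnc(Nc3ccc(Oc4ccnc5cc(OCCO)ccc45)c(F)c3)c12` gives 3500 nM

Compound 3 stands second highest among the three numbers. Its nearest neighbour is compound 1 and its furthest is compound 2, yet both gaps fall within the scatter, so the three compounds cannot be told apart on these numbers. Compound 4 `CC(O)COc1ccc2c(Oc3ccc(Nc4nccc5[nH]cc(-c6ccc(F)cc6)c(=O)c45)cc3F)ccnc2c1` is not yet measured. It differs from compound 3 in one place: methyl in place of hydrogen on a saturated chain carbon bound to an oxygen on a saturated carbon and a saturated chain carbon. Going by the values given here, no step between measured compounds isolates this change, so there is no measured precedent. The three values sit closely together, and a single methyl on the chain is expected to move the number little, with the step of a 1.0-fold lower number from compound 3 to compound 4 (0.01 log units; within the scatter) expected to remain within the scatter. Compound 4 is therefore estimated at 3400 nM, between 1700 nM and 7000 nM.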

Compound 4, half-maximal inhibitory concentration: 3400 nM
Compound 4: the middle estimate sits on the measured number at the digits printed; measured number inside the range.
By their numbers in this assay, from the lowest: compounds 2, 4, 3 and 1 (each within the scatter of the next).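

Going by these compounds alone, replacing 2-hydroxyethoxy with 2-hydroxypropoxy gives the first single-change step on this side chain in this assay, a 1.0-fold lower number from compound 3 to compound 4 (0.01 log units; within the scatter), so a methyl on this saturated chain carbon does not separate compound 4 from compound 3. Within the data shown here, this single step is the only reading of the change, and it concerns this one chain and core. No supporting measurement bears on the result. From the compounds shown here alone, whether an amine or a carboxylic acid in place of the hydroxyl, or a longer chain at this carbon, would give a number beyond the scatter remains open.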